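A few compounds are considered here, and "the series" means these few. Any claim that something is new, unique, unknown or untested is made for them only; others in the source may bear on it.

Measured in an ADME assay on microsomes from liver (Homo sapiens) for metabolic stability, read by LC-MS, with a stated time of 40 min, tested at 0.5 uM; a lower number here means slower removal, a higher number faster removal of the compound:

- compound 1 `CC(C)(C)NS(=O)(=O)c1cccc(NC(=O)c2ccc(NS(=O)(=O)C3(C)CC3)cc2N2CCC3(CC2)CC3)c1`: 90 mL.min-1.g-1
- compound 2 `CC1(C)CCN(c2ncccc2C(=O)Nc2cccc(S(=O)(=O)C3CCCC3)c2)CC1`: > 399 mL.min-1.g-1 (a limit, not a number)
- compound 3 `O=C(Nc1cccc(S(=O)(=O)C2COC2)c1)c1cccnc1N1CCC2(CC1)CC2`: 183 mL.min-1.g-1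

Compound 2 is the only one of these three without a true number, and its reading stands at the limit of > 399 mL.min-1.g-1 in this assay, at which 1 of the 3 values shown sits. This gives the next comparison an open end, since the starting point is a limit.

Compound 4 `O=C(Nc1cccc(S(=O)(=O)C2CCCC2)c1)c1cccnc1N1CCCCC1` has not yet been measured. It differs from compound 2 in one place: piperidin-1-yl in place of 4,4-dimethylpiperidin-1-yl on an aromatic carbon. Here piperidin-1-yl takes the place of 4,4-dimethylpiperidin-1-yl on an aromatic carbon, and the rest of compound 2 stays as it is.

Within the data shown here, no measured pair in this set isolates such a change, so any expectation is rough. Compound 1 gives 90 mL.min-1.g-1 and compound 3 gives 183 mL.min-1.g-1, which shows that true numbers occur here, but each of them differs from compound 2 in more than one place. A modest fall in this assay is therefore expected, and a reading that again reaches the limit would be no surprise. The expected change is an at least 1.3-fold lower number from compound 2 to compound 4 (0.12 log units; that floor lies within the scatter). For compound 4 the estimated value is 300 mL.min-1.g-1, with an expected range from 150 mL.min-1.g-1 to 600 mL.min-1.g-1.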

Compound 4, intrinsic clearance in microsomes: > 399 mL.min-1.g-1
Compound 4: no number, only a limit; the forecaster's own chance of this, stated with the estimate: 35%; middle value at least 1.3-fold (0.12 log units) away from the limit.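

Compound 2 and compound 4 both give a limit rather than a number in this assay, so no step can be read between them: the limit of > 399 mL.min-1.g-1 in this assay, at which 2 of the 4 values shown sit.

The compounds shown leave open how fast compound 2 and compound 4 are actually removed, and whether piperidin-1-yl in place of 4,4-dimethylpiperidin-1-yl changes that rate at all.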